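A few compounds are considered here, and "the series" means these few. Any claim that something is new, unique, unknown or untested is made for them only; others in the source may bear on it.

In a functional assay on HL-60 cells (Homo sapiens) for cytotoxicity, with a stated time of 24 h (on this read-out lower numbers stand for higher toxicity in this test and higher numbers for lower toxicity in this test), compound 1 (`O=C1/C(=C/c2ccc(F)cc2)CCC/C1=C\c1cccc([N+](=O)[O-])c1`) gives 1000 nM and compound 2 (`O=C1/C(=C/c2ccc(Cl)cc2)CCC/C1=C\c1cccc([N+](=O)[O-])c1`) gives 3200 nM on the same read-out. Compound 3 (`CN(C)c1ccc(/C=C2\CCC/C(=C\c3cccc([N+](=O)[O-])c3)C2=O)cc1`) gives 30000 nM as the highest of the three numbers, and compound 2 is its nearest neighbour.

The next step leads to compound 4 (`Cc1ccc(/C=C2\CCC/C(=C\c3cccc([N+](=O)[O-])c3)C2=O)cc1`). The change is methyl in place of dimethylamino on an aromatic carbon and amounts to methyl in place of dimethylamino on an aromatic carbon, para to a large group.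

All three measured steps concern this same substituent. Two of them bring in dimethylamino: a 30-fold higher number from compound 1 to compound 3 (1.48 log units; beyond the scatter) (large) with fluoro leaving and a 9.4-fold higher number from compound 2 to compound 3 (0.97 log units; beyond the scatter) (modest) with chloro leaving. The exchange of fluoro for chloro, a 3.2-fold higher number from compound 1 to compound 2 (0.51 log units; beyond the scatter) (modest), is the smallest of the three. Going by the values given here, no methyl compound has been measured, so its place relative to fluoro and chloro remains open. Replacing dimethylamino is nevertheless expected to undo much of the rise seen in those two steps, which points to a lower number in this assay by a modest to large step beyond the scatter.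

The expected step is a 10-fold lower number from compound 3 to compound 4 (1.00 log units; beyond the scatter) towards higher toxicity in this test. For compound 4 the estimated value is 3000 nM with an expected range from 1000 nM to 10000 nM on this read-out.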

Compound 4, half-maximal cytotoxic concentration: 38000 nM
The estimate for compound 4 lay 13-fold (1.10 log units) below the measured number; the measured number lies above the stated range.
By their numbers in this assay, from the lowest: compound 1; then compound 2; then compounds 3 and 4 (each within the scatter of the next).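

In this assay the exchange of dimethylamino for methyl at this position, para to a large group, gives a 1.3-fold higher number from compound 3 to compound 4 (0.10 log units; within the scatter) and so does not separate the two groups. High numbers at this position therefore do not depend on dimethylamino alone, and a substituent with no nitrogen gives a value within the scatter of compound 3. Methyl stands well apart from both halogens, with a 12-fold higher number from compound 2 to compound 4 (1.07 log units; beyond the scatter) and a 38-fold higher number from compound 1 to compound 4 (1.58 log units; beyond the scatter) as its steps, so the four compounds read as fluoro, then chloro, then methyl and dimethylamino together, and none of the four goes against this order; nothing available bears on why the substituents fall this way.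

On these data alone, whether low numbers at this position belong to the halogens alone stays open, and bromo, trifluoromethyl, methoxy or plain hydrogen on the same aromatic carbon of the shared core would test this. Also open, as far as these compounds go, is whether the same order holds when the nitro group on the other aromatic ring gives way to a nitrile or an amine.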